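Morpholin-4-yl in place of pyrrolidin-1-yl on a carbonyl carbon

The source may hold more compounds than are shown below. What is called first, only, known or untested is meant among the compounds shown, and "the series" means these compounds.

Measured so far in a functional assay on MDA-MB-231 cells (Homo sapiens) for antiproliferative activity, read by MTT assay, with a stated time of 24 h; a lower number here means a stronger inhibitor, a higher number a weaker inhibitor
compound 1 `CCCCNC(=O)COc1ccc(C(=O)c2c(CCCC)oc3ccccc23)cc1` gives 34500 nM
compound 2 `CCCCc1oc2ccccc2c1C(=O)c1ccc(OCC(=O)N2CCCC2)cc1` gives > 50000 nM

In this assay compound 2 stands at > 50000 nM and this is a limit of the assay, not a number. Compound 3 `CCCCc1oc2ccccc2c1C(=O)c1ccc(OCC(=O)N2CCOCC2)cc1` keeps the shared core and differs from compound 2 by morpholin-4-yl in place of pyrrolidin-1-yl on a carbonyl carbon in one place, with morpholin-4-yl in place of pyrrolidin-1-yl on a carbonyl carbon. Going by the values given here, only one measured step bears on this place, namely an at least 1.4-fold higher number from compound 1 to compound 2 (0.16 log units; that floor lies within the scatter) and its floor gives no firm size. On that single step, no change beyond the scatter is expected in this assay in either direction. The expected step is a number no higher from compound 2 to compound 3 (the limit leaves the size open) and the assay may again report only a limit. For compound 3 the estimated value is 50000 nM with an expected range from 25000 nM to 100000 nM in this estimate.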

Compound 3, half-maximal inhibitory concentration: > 50000 nM
Compound 3: no number, only a limit; the forecaster's own chance of this, stated with the estimate: 55%; the middle value lies on the limit itself.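

In this assay compound 3 gives > 50000 nM, which is a limit of the assay and not a number. With morpholin-4-yl in place of butylamino on the carbonyl carbon, the result is an at least 1.4-fold higher number from compound 1 to compound 3 (0.16 log units; that floor lies within the scatter), so this second ring also yields only a floor within the scatter and no firm size, while the step between the two rings cannot be read. What can be read at this position is restricted by the assay limit: the limit of > 50000 nM in this assay, at which 2 of the 3 values shown sit.

The compounds shown leave open whether pyrrolidin-1-yl and morpholin-4-yl differ at all in this assay. They also leave open how a longer chain such as hexylamino would stand against butylamino, and whether a ring such as piperidin-1-yl would return a number rather than a limit.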